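The source may hold more compounds than are shown below. What is called first, only, known or untested is meant among the compounds shown, and "the series" means these compounds.

The study set out two measured compounds in a functional assay on the whole organism (strain Wistar) for inhibition, with Rattus norvegicus as the target, read by paw edema, with a stated time of 3 h, at a dose of 100 umol/kg by the oral route; on this read-out lower numbers stand for less inhibition and higher numbers for more inhibition at the one dose given (going by the name of the read-out). Compound 1, `c1ccc(Nc2c(-c3ccccc3)nc3ccccn23)cc1`, gives 63.9% in this assay, the higher of the two numbers recorded. Compound 2, `CS(=O)(=O)c1ccc(-c2nc3ccccn3c2Nc2ccccn2)cc1`, gives 17.2% in this assay, a number that falls beyond the scatter below that of compound 1. For the measured compounds named here, for this pair no step is worked out, so the two values show only that compound 2 sits well below compound 1.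

Compound 3, `c1ccc(Nc2c(-c3ccncc3)nc3ccccn23)cc1`, has not yet been measured in this assay. It differs from compound 1 in one place: pyridin-4-yl in place of phenyl on an aromatic carbon. Going by the values given here, no pair of measured compounds that differ in a single place is available, so the size of such a change cannot be read from any measured step. Compound 3 is therefore expected to stay fairly close to compound 1, with a step of a number 13.9 percentage points lower from compound 1 to compound 3 (beyond the scatter) that is expected to run somewhat downward but may not pass beyond the scatter. On this basis compound 3 is estimated at 50% in this assay, within a range from 25% to 75%.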

Compound 3, a percentage reported as inhibition, in the whole organism at one dose (the size of the read-out at that dose, not a potency): 49.9%
Beside the measured number, compound 3's estimate is 0.1 percentage points above it, within the range that was stated.
By their numbers in this assay, from the lowest: compound 2; then compound 3; then compound 1.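

In this assay, for the compounds shown here, pyridin-4-yl in place of phenyl on the aromatic carbon next to the ring nitrogen gives a number 14 percentage points lower from compound 1 to compound 3 (beyond the scatter), the first step that can be read from a change in one place. It shows that this position is not indifferent to a modest exchange, even though the heavy-atom count stays the same and the entering ring differs by one ring nitrogen and one hydrogen-bond acceptor; the step is modest, and compound 3 still gives 49.9%. Nothing available explains the drop, so no cause can be assigned to it.

This single step, read at one dose and one time, does not tell whether the placement of the ring nitrogen matters, as pyridin-3-yl or pyridin-2-yl at this position would show, or how a phenyl carrying a methylsulfonyl group, an amine or a carboxylic acid would behave there. On these data alone, compound 2 differs from compound 1 and compound 3 in more than one place, so the share of each of its changes remains open.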